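The source may hold more compounds than are shown below. What is called first, only, known or untested is meant among the compounds shown, and "the series" means these compounds.

Compound 1, `Cn1cnc2c(Nc3ccccc3)ncnc21`, was tested in an assay on isolated protein for inhibition of Ca2+/calmodulin-dependent protein kinase II (CaM kinase II) (Rattus norvegicus), tested at 30 uM (on this read-out lower numbers stand for less inhibition and higher numbers for more inhibition at the one concentration tested (going by the name of the read-out)), where compound 1 gives 0%. Compound 2, `Cn1cnc2c(Nc3ccc(F)cc3)ncnc21`, differs from compound 1 by a single change, (fluoro in place of hydrogen on an aromatic carbon). In this assay compound 2 gives 8%, so the step is a number 8 percentage points higher from compound 1 to compound 2 (within the scatter); a gap of that size is one that repeated measurements of this kind can produce on their own, and it therefore does not show a real difference between the two compounds.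

Compound 3, `Cn1cnc2c(SCc3ccccc3)ncnc21`, carries a different core from compound 1; how the two cores differ is not broken down here. In this assay compound 3 gives 0%, level with compound 1 at the digits recorded and within the scatter of compound 2.

Compound 4, `Cn1cnc2c(SCc3ccc(F)cc3)ncnc21`, has not yet been measured. It stands to compound 3 as compound 2 stands to compound 1: the change is fluoro in place of hydrogen on an aromatic carbon, with the place described in the same words in both cases, so it is the same change made on another core. Among the four compounds this change occurs twice in all. For the measured compounds named here, the expected step from compound 3 to compound 4 is a number 4 percentage points higher from compound 3 to compound 4 (within the scatter), resting on the only measured example of the change, which is a number 8 percentage points higher from compound 1 to compound 2 (within the scatter). On that basis compound 4 is expected to give about 4% in this assay, with a plausible range estimated from -6% to 14%.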

Compound 4, a percentage reported as inhibition, at one concentration (the size of the read-out at that concentration, not a potency): 5%
Beside the measured number, compound 4's estimate is 1 percentage points below it; the measured number falls inside the stated range.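

In this assay, fluoro in place of hydrogen on an aromatic carbon gives a number 5 percentage points higher from compound 3 to compound 4 (within the scatter), and set beside the earlier example, the two steps agree: the same change on two cores in this assay, a number 8 percentage points higher (within the scatter) from compound 1 to compound 2 and a number 5 percentage points higher (within the scatter) from compound 3 to compound 4, 3 percentage points apart, within the scatter of two such steps. Carrying the change from one core to the other therefore gives no sign of a different outcome, and these two pairs offer no reason to treat the cores separately for this change. Each step on its own lies within the scatter, however, so neither pair shows that fluoro alters inhibition at all, and agreement between two such small steps does not prove that the change has the same real effect on both cores or predict its effect on a further core.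

The compounds shown leave open what other groups on the same aromatic carbon, such as chloro, methoxy, an amine or a carboxylic acid, would do, and whether any of them would produce a step beyond the scatter in this read-out. They also leave open how fluoro would behave on other carbons of the ring, and whether a longer chain in place of the link to the ring would change the picture on either core.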